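Swapping Nitro for Chloro in an Inactive Sulfonamide Set

The source may report more compounds than this note shows. Statements on the series, on what has been measured and on what is new or still open speak of the compounds shown alone.

Compound 1, `CCOC(=O)c1oc2ccc(NS(=O)(=O)c3ccc(Cl)cc3)cc2c1C`, in a functional assay on HCT-116 cells (Homo sapiens) for inhibition, read by MTT assay, with a stated time of 72 h (a lower number here means a stronger inhibitor, a higher number a weaker inhibitor), gives > 40000 nM, a limit of the assay rather than a number.
Compound 2, `CCOC(=O)c1oc2ccc(N(Cc3ccccc3)S(=O)(=O)c3ccc(C)cc3)cc2c1C`, gives in this assay > 40000 nM, also a limit.
Compound 3, `CCOC(=O)c1oc2ccc(N(Cc3ccccc3)S(=O)(=O)c3ccc([N+](=O)[O-])cc3)cc2c1C`, gives in this assay > 40000 nM, again a limit.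

Compound 3 therefore stands at the limit, as do the others (the limit of > 40000 nM in this assay, at which 3 of the 3 values shown sit). Going by the values given here, the one step between neighbours, a step that the two limits leave unreadable from compound 2 to compound 3, cannot be read because both ends are limits. Compound 4, `CCOC(=O)c1oc2ccc(N(Cc3ccccc3)S(=O)(=O)c3ccc(Cl)cc3)cc2c1C`, differs from compound 3 by chloro in place of nitro on an aromatic carbon. Among the compounds with values here, no measured step resolves this change, and compound 1, which carries the same chloro group, also sits at the limit. Compound 4 is therefore expected to remain at the limit, an estimated 60000 nM (range 20000 nM to 200000 nM), a step that the limit leaves unreadable from compound 3 to compound 4 that is expected to be unreadable.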

Compound 4, half-maximal inhibitory concentration: 23200 nM
Beside the measured number, compound 4's estimate is 2.6-fold (0.41 log units) above it, and the stated range covers the measured number.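

Going by these compounds alone, compound 4, with chloro on this aromatic carbon, gives the only value in this assay that is not a limit, and the change reads as an at least 1.7-fold lower number from compound 3 to compound 4 (0.23 log units; that floor lies within the scatter), and as an at least 1.7-fold lower number from compound 2 to compound 4 (0.23 log units; that floor lies within the scatter). With chloro kept, putting benzyl on the sulfonamide nitrogen reads as an at least 1.7-fold lower number from compound 1 to compound 4 (0.23 log units; that floor lies within the scatter), and none of these three floors shows a change beyond the scatter. Every other compound stays at a limit: the limit of > 40000 nM in this assay, at which 3 of the 4 values shown sit.

On these data alone, the true size of all three steps remains open. Also open, as far as these compounds go, is whether an amine or a carboxylic acid in this place, or a longer chain in place of benzyl, would give a lower number.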